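Adding a Third Methoxy to an Inactive Pair

A few compounds are considered here, and "the series" means these few. Any claim that something is new, unique, unknown or untested is made for them only; others in the source may bear on it.

Compound 1, `COc1ccc(-c2nnc(-c3c[nH]c4ccccc34)o2)cc1`: in a functional assay on MIA PaCa-2 cells (Homo sapiens) for cytotoxicity, read by MTT assay (on this read-out higher numbers stand for weaker inhibition and lower numbers for stronger inhibition), compound 1 gives > 1000000 nM, which is a limit of the assay and not a number.
Compound 2, `COc1ccc(-c2nnc(-c3c[nH]c4ccccc34)o2)cc1OC`: in this assay compound 2 gives > 1000000 nM, likewise a limit of the assay.

Compound 2 therefore stands at the limit of this assay, and every value shown so far sits there too: the limit of > 1000000 nM in this assay, at which 2 of the 2 values shown sit. Among the compounds with values here, the single measured step, a step that the two limits leave unreadable from compound 1 to compound 2, adds a methoxy to an aromatic carbon, yet its size cannot be read from two limits.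

Compound 3, `COc1ccc(-c2nnc(-c3c[nH]c4ccccc34)o2)c(OC)c1OC`, takes the same kind of change one stage further: methoxy in place of hydrogen on an aromatic carbon.

Within the data shown here, the only step that bears on this change has no readable size, so nothing in the data points to a step beyond the scatter in this assay, in either direction. Compound 3 is expected to give about 1000000 nM, within 200000 nM to 5000000 nM, most probably reported again only as a limit. The estimate thus means a number no higher from compound 2 to compound 3 (the limit leaves the size open), an expected step of no size beyond the scatter.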

Compound 3, half-maximal inhibitory concentration: > 1000000 nM
Compound 3 ended at the assay's limit (the forecaster's own chance of this, stated with the estimate: 85%); the middle value sits exactly at the limit.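

Compound 2 and compound 3 each give a limit of the assay and not a number, so no size can be read for the step between them: the limit of > 1000000 nM in this assay, at which 3 of the 3 values shown sit.

The compounds shown leave open whether either methoxy addition changes inhibition at all in this assay.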